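The compounds below may be only part of what the source reports. "The series", "measured", "known", "first", "only" and "open" are said of these compounds alone.

In a functional assay on A498 cells (Homo sapiens) for cytotoxicity, read by sulforhodamine B assay, with a stated time of 48 h (on this read-out lower numbers stand for stronger inhibition of growth and higher numbers for weaker inhibition of growth), compound 2 `ClCc1cccc(Cn2cnc3c(Cl)ncnc32)c1` gives 31600 nM. For the measured compounds named here, its only neighbour, compound 1 `ClCc1ccc(Cn2cnc3c(Cl)ncnc32)cc1`, gives 26900 nM in this assay, a value that sits within the usual scatter of the one for compound 2, so the two cannot be told apart. Compound 3 `ClCc1cccc(Cn2cnc3c(Cl)nc(Cl)nc32)c1` differs from compound 2 by chloro in place of hydrogen on an aromatic carbon. Going by the values given here, no measured pair shows this change, so in this assay only a modest step, if any beyond the scatter, is expected, with the direction open. Compound 3 is therefore estimated at 25000 nM, within 8000 nM to 70000 nM, an expected step of a 1.3-fold lower number from compound 2 to compound 3 (0.10 log units; within the scatter).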

Compound 3, concentration for total growth inhibition: 6600 nM
Beside the measured number, compound 3's estimate is 3.8-fold (0.58 log units) above it; measured number below the stated range.
By their numbers in this assay, from the lowest: compound 3; then compounds 1 and 2 (each within the scatter of the next).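

In this assay, chloro in place of hydrogen on the aromatic carbon between two ring nitrogen atoms gives a 4.8-fold lower number from compound 2 to compound 3 (0.68 log units; beyond the scatter) and so separates two compounds, which compound 1 and compound 2 did not do. This position therefore responds to a single added chlorine atom. Nothing available accounts for the step.

As far as these compounds go, whether an amine or a methoxy group on this carbon would move the number the same way remains open. So does whether chloro here has a similar effect on the core of compound 1.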